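The source may hold more compounds than are shown below. What is called first, only, known or untested is meant among the compounds shown, and "the series" means these compounds.

For the measured compounds named here, in an assay for inhibition of Polyunsaturated fatty acid 5-lipoxygenase (Homo sapiens), tested at 1 uM (on this read-out lower numbers stand for a stronger effect and higher numbers for a weaker effect at the one concentration tested), two compounds have numbers so far. Compound 1 `CCCCC(Sc1nc(Cl)cc(Nc2ccc3ncccc3c2)n1)C(=O)OCC` gives 51.8% in this assay. Compound 2 `CCCCCCC(Sc1nc(Cl)cc(Nc2cccc(C)c2C)n1)C(=O)OCC` gives 84.9% in this assay, which is the higher of the two numbers; the gap between compound 2 and compound 1 lies beyond the usual scatter, so compound 2 shows the weaker effect of the pair at the concentration tested.

Compound 3 `CCOC(=O)C(Sc1nc(Cl)cc(Nc2cccc(C)c2C)n1)c1ccccc1` has not yet been measured. It differs from compound 2 in a single place: phenyl in place of hexyl on a saturated chain carbon bound to a carbonyl carbon and a sulfur. Going by the values given here, no step between two measured compounds shows how an exchange of this kind moves the read-out, so nothing in the measured pair tells which way compound 3 will go, and the expectation rests on compound 2 alone. With that in mind, only a small move is expected, and the step is estimated as a number 9.9 percentage points lower from compound 2 to compound 3 (within the scatter). Compound 3 is therefore expected to give about 75% in this assay, within a range from 45% to 100%.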

Compound 3, a percentage reported as activity, at one concentration (the size of the read-out at that concentration, not a potency): 53.1%
Estimate against measurement, compound 3: 21.9 percentage points above, within the range that was stated.
By their numbers in this assay, from the lowest: compounds 1 and 3 (each within the scatter of the next); then compound 2.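

In this assay, for the compounds shown here, the exchange of hexyl for phenyl on the saturated chain carbon bound to a carbonyl carbon and a sulfur gives a number 31.8 percentage points lower from compound 2 to compound 3 (beyond the scatter), the first step that can be read in one place. This shows that the read-out responds to what sits at this carbon, even though the group that leaves and the group that enters each hold 6 heavy atoms, all carbon, with no hydrogen-bond donors or acceptors and no net charge; what differs in the count is the six-membered aromatic ring, and here the ring goes with the stronger effect at the concentration tested. No measurement at hand explains why this exchange moves the read-out.

A single step cannot show whether the ring itself matters or whether other groups at this carbon, such as methyl, benzyl or a pyridyl ring, would give a similar number. It also leaves open whether phenyl in place of hexyl would move the read-out the same way on the core of compound 1, or with a carboxylic acid in place of the ethyl ester.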